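The compounds below may be only part of what the source reports. "The series", "measured", "known", "first", "only" and "open" are said of these compounds alone.

Compound 1, `Cc1nc(-c2ccc(Cl)cc2)sc1C(=O)CSc1nc(-c2ccc(Cl)c(Cl)c2)c(C#N)c(=O)[nH]1`, gives 93.9% in a functional assay on U-87MG ATCC cells for antiproliferative activity against U-87 MG (Homo sapiens), read by MTT assay, with a stated time of 48 h, tested at 50 uM; a higher number here means a weaker effect of the compound at the concentration tested, a lower number a stronger effect.
Compound 2, `COc1ccc(-c2nc(SCC(=O)c3sc(-c4ccc(Cl)cc4)nc3C)[nH]c(=O)c2C#N)cc1`, gives 46.3% in this assay.

Compound 2 stands lowest of the two numbers, so at this concentration it has the stronger effect of the pair. Going by the values given here, the only measured step, a number 47.6 percentage points lower from compound 1 to compound 2 (beyond the scatter), is large and beyond the scatter; it comes from putting 4-methoxyphenyl in place of 3,4-dichlorophenyl on an aromatic carbon.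

Compound 3, `COc1ccc(-c2nc(SCC(=O)c3sc(-c4ccc(Cl)cc4)nc3C)[nH]c(=O)c2C#N)cc1OC`, is the next step from compound 2: methoxy in place of hydrogen on an aromatic carbon. Read one bond further out, this turns 4-methoxyphenyl into 3,4-dimethoxyphenyl. Among the compounds with values here, no measured step adds a group at this place; the one step known swaps the whole ring substitution at once and therefore bears on this change only loosely. It shows that what sits on this ring can move the number a great deal, but it gives no direction for a single added methoxy. The expected step is therefore none beyond the scatter, as a number 3.7 percentage points higher from compound 2 to compound 3 (within the scatter), with wide uncertainty. Compound 3 is estimated at 50%, in the range 22% to 80% in this assay.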

Compound 3, a percentage reported as activity, at one concentration (the size of the read-out at that concentration, not a potency): 59.8%
For compound 3 the middle estimate is 9.8 percentage points below the measured one; low and high end bracket the measured number.
By their numbers in this assay, from the lowest: compound 2; then compound 3; then compound 1.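

The single added methoxy, on the ring carbon ortho to a methoxy group, weakens the effect: the read-out in this assay moves by a number 13.5 percentage points higher from compound 2 to compound 3 (beyond the scatter), a modest step. So this carbon of the 4-methoxyphenyl ring is not neutral to substitution, and 3,4-dimethoxyphenyl gives up part of what 4-methoxyphenyl gained over 3,4-dichlorophenyl. Even so, the 3,4-dimethoxyphenyl compound keeps most of that gain, with a number 34.1 percentage points lower from compound 1 to compound 3 (beyond the scatter), so a ring carrying two methoxy groups still acts much more strongly at this concentration than one carrying two chlorines, and nothing available explains why either change shifts the number as it does.

As far as these compounds go, it remains open whether the weaker effect belongs to methoxy in particular or would follow any group on this carbon, such as a hydroxy group, an amine or a longer ethoxy chain. A single concentration also leaves open how the potencies of these three compounds compare, since each number gives only the size of the read-out at that concentration.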